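The source may report more compounds than this note shows. Statements on the series, on what has been measured and on what is new or still open speak of the compounds shown alone.

Compound 1 `COc1cc(C(=O)c2sc(-c3ccc(F)cc3)cc2N)cc(OC)c1OC`: 15 nM
Compound 2 `COc1cc(C(=O)c2sc(-c3ccc(C(F)(F)F)cc3)cc2N)cc(OC)c1OC`: 270 nM
Compound 3 `COc1cc(C(=O)c2sc(-c3ccc([N+](=O)[O-])cc3)cc2N)cc(OC)c1OC`: 99 nM

All three share one core and differ only in the group para to a large group on the outer ring. In a functional assay on CCRF-CEM cells (Homo sapiens) for antiproliferative activity (a higher number here means a weaker inhibitor, a lower number a stronger inhibitor), compound 2 gives the highest number of the three: the step of a 2.7-fold lower number from compound 2 to compound 3 (0.44 log units; beyond the scatter) and the step of an 18-fold higher number from compound 1 to compound 2 (1.26 log units; beyond the scatter) both lie beyond the scatter, so compound 2 is the weakest inhibitor measured here.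

Compound 4 `COc1cc(C(=O)c2sc(-c3ccc(Br)cc3)cc2N)cc(OC)c1OC` carries the change (bromo in place of trifluoromethyl on an aromatic carbon). Going by the values given here, no measured compound has bromo at that place, so the expectation rests on two comparisons: an 18-fold higher number from compound 1 to compound 2 (1.26 log units; beyond the scatter) shows a large loss when fluoro gives way to trifluoromethyl, and a 2.7-fold lower number from compound 2 to compound 3 (0.44 log units; beyond the scatter) shows part of it regained with nitro. Removing trifluoromethyl again is therefore expected to lower the number for compound 4, by about a 5.4-fold lower number from compound 2 to compound 4 (0.73 log units; beyond the scatter), to an estimated 50 nM with a range of 15 nM to 180 nM.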

Compound 4, half-maximal inhibitory concentration: 86 nM
Beside the measured number, compound 4's estimate is 1.7-fold (0.24 log units) below it, and the stated range covers the measured number.
By their numbers in this assay, from the lowest: compound 1; then compounds 4 and 3 (each within the scatter of the next); then compound 2.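

Bromo at this place recovers part of what trifluoromethyl loses in this assay (a 3.1-fold lower number from compound 2 to compound 4 (0.50 log units; beyond the scatter)), but it does not match fluoro (a 5.7-fold higher number from compound 1 to compound 4 (0.76 log units; beyond the scatter)). Bromo and nitro cannot be told apart (a 1.2-fold lower number from compound 3 to compound 4 (0.06 log units; within the scatter)), so two different groups give the same level here, and fluoro remains clearly ahead of the other three. Nothing available explains this ranking.

Still open, on these data alone, is whether chloro, methoxy or an amine at this place would come close to fluoro. Also open, as far as these compounds go, is how a plain hydrogen there would compare with these four groups.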